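The source may hold more compounds than are shown below. What is called first, only, known or untested is meant among the compounds shown, and "the series" means these compounds.

Measured so far in a functional assay for inhibition of sodium/hydrogen exchanger (Oryctolagus cuniculus); a lower number here means a stronger inhibitor, a higher number a weaker inhibitor:

compound 1, `Cc1cc(C2CCCCC2)c(S(C)(=O)=O)cc1C(=O)N=C(N)N`: 22 nM
compound 2, `Cc1cc(-c2ccc(F)cc2)c(S(C)(=O)=O)cc1C(=O)N=C(N)N`: 36 nM
compound 3, `Cc1cc(-c2cc(Cl)cc(Cl)c2)c(S(C)(=O)=O)cc1C(=O)N=C(N)N`: 130 nM

Compound 1 stands at the lowest of the three numbers in this assay. Its gap to compound 2, a 1.6-fold higher number from compound 1 to compound 2 (0.21 log units; within the scatter), lies within the scatter, so the two cannot be ordered; the gap to compound 3, a 5.9-fold higher number from compound 1 to compound 3 (0.77 log units; beyond the scatter), is beyond it, as is a 3.6-fold higher number from compound 2 to compound 3 (0.56 log units; beyond the scatter).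

Compound 4, `CS(=O)(=O)c1cc(C(=O)N=C(N)N)ccc1C1CCCCC1`, differs from compound 1 by hydrogen in place of methyl on an aromatic carbon. Among the compounds with values here, none of the measured steps touches this methyl; all three exchange the cyclohexyl for an aryl group. They bear on the new step only indirectly, showing that the shared core of compound 1 answers changes at its periphery with shifts ranging from within the scatter to modest. Within the data shown here, with no direct precedent, for compound 4 the step is expected to be small and, if anything, toward a slightly higher number, a 2.0-fold higher number from compound 1 to compound 4 (0.31 log units; beyond the scatter). Compound 4 is therefore estimated at 45 nM in this assay, within a range from 15 nM to 140 nM.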

Compound 4, half-maximal inhibitory concentration: 340 nM
The estimate for compound 4 lay 7.6-fold (0.88 log units) below the measured number; measured number outside the range, above it.
By their numbers in this assay, from the lowest: compounds 1 and 2 (each within the scatter of the next); then compound 3; then compound 4.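

In this assay, hydrogen in place of the methyl, which stands meta to a cyclohexyl group and para to a methylsulfonyl group, gives a 15-fold higher number from compound 1 to compound 4 (1.19 log units; beyond the scatter), a large step. Within the data shown here, the loss of this one carbon thus moves the number further than the widest change among the earlier compounds, a 5.9-fold higher number from compound 1 to compound 3 (0.77 log units; beyond the scatter), so this position answers more strongly than the aryl exchanges had suggested for the periphery of the shared core. Nothing available here accounts for the size of the step.

The compounds shown do not tell whether the methyl matters equally when a 4-fluorophenyl or 3,5-dichlorophenyl group replaces the cyclohexyl. They also leave open how an ethyl group, a chlorine atom or a methoxy group at this position would compare with the methyl.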